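The source may hold more compounds than are shown below. What is called first, only, known or untested is meant among the compounds shown, and "the series" means these compounds.

Measured in an ADME assay on HEL cells (Homo sapiens) for cytotoxicity; on this read-out lower numbers stand for higher toxicity in this test and higher numbers for lower toxicity in this test
- compound 1 `O=C(COc1cccc2ccccc12)N/N=C/c1ccccc1Br` gives 100 ug/mL
- compound 2 `O=C(COc1cccc2ccccc12)N/N=C/c1ccc(F)cc1` gives 71.6 ug/mL

Among the compounds with values here, compound 2 lies within the scatter of compound 1, the only other measured compound, so these two values do not separate the pair. The next compound to be measured is compound 3 `O=C(COc1cccc2ccccc12)N/N=C/c1cccc(Cl)c1` and the structural change leading to it is 3-chlorophenyl in place of 4-fluorophenyl on a carbon with a double bond to nitrogen (in words, 3-chlorophenyl in place of 4-fluorophenyl on a carbon with a double bond to nitrogen). The rest of the structure stays the same.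

Within the data shown here, one measured step bears on this change, as it also exchanges the group at that place, namely a 1.4-fold lower number from compound 1 to compound 2 (0.15 log units; within the scatter) (4-fluorophenyl in place of 2-bromophenyl). Among the measured compounds shown here, that step stays within the scatter, although it is only a single step, and no measured compound carries 3-chlorophenyl. The step therefore supports only a cautious expectation of no shift beyond the scatter in this assay and the range has to stay wide. The expected step is a 1.0-fold lower number from compound 2 to compound 3 (0.01 log units; within the scatter) (an estimate, not a measurement). Compound 3 is estimated at 70 ug/mL (expected range 30 ug/mL to 110 ug/mL).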

Compound 3, half-maximal cytotoxic concentration: 58.6 ug/mL
Compound 3: the middle estimate sits 1.2-fold (0.08 log units) above what was measured, within the range that was stated.
By their numbers in this assay, from the lowest: compounds 3, 2 and 1 (each within the scatter of the next).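

In this assay, 3-chlorophenyl on a carbon with a double bond to nitrogen gives a 1.2-fold lower number from compound 2 to compound 3 (0.09 log units; within the scatter) and a 1.7-fold lower number from compound 1 to compound 3 (0.23 log units; within the scatter), and both steps stay within the scatter. With this result, all three pairs among 2-bromophenyl, 4-fluorophenyl and 3-chlorophenyl are within the scatter, so a third halogen-bearing phenyl group at this place still does not separate the compounds in this read-out, and the widest gap in the series, the step to compound 3 from compound 1, does not do so either. No supporting measurement is available that could account for this flat picture.

On these data alone, whether an amine or a carboxylic acid on the phenyl ring, or a longer chain in place of the phenyl ring, would give a step beyond the scatter at this place remains open. The effect of a change elsewhere in the shared core on this read-out also remains open, as the compounds shown differ only in the group on this carbon.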